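A few compounds are considered here, and "the series" means these few. Any claim that something is new, unique, unknown or untested is made for them only; others in the source may bear on it.

Measured so far:
- compound 1, `O=C(Nc1cccc(Cl)c1)O/N=C(\C1CCCCC1)C(Cn1ccnc1)C1CCCCC1`: in an assay on isolated protein for displacement of a labelled ligand from metabotropic glutamate receptor 5 (Rattus norvegicus) (a higher number here means a weaker inhibitor, a lower number a stronger inhibitor), compound 1 gives 10.8 nM; 8.78 nM; 1000 nM (3 entries)
- compound 2, `O=C(Nc1cccc(F)c1)O/N=C(\C1CCCCC1)C(Cc1cccs1)C1CCCCC1`: in this assay compound 2 gives 12.3 nM

Compound 1 has more than one entry, and the several entries of compound 1 in this assay, 10.8 nM; 8.78 nM; 1000 nM (3 entries) shows that one of its entries lies far from the others, so its value should be read with care. Compound 2 has a single number in this assay, with one further entry that gives no single number, and that one number places it close to the lower entries of compound 1.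

The next compound, compound 3, `Cc1cccc(NC(=O)O/N=C(\C2CCCCC2)C(Cc2cccs2)C2CCCCC2)c1`, differs from compound 2 only by methyl in place of fluoro on an aromatic carbon. Going by the values given here, no measured pair shows what this exchange does, so the expectation rests on the small size of the swap alone. The step from compound 2 to compound 3 in this assay is expected to be a 1.0-fold lower number from compound 2 to compound 3 (0.01 log units; within the scatter), that is, no change beyond the usual scatter in either direction. Compound 3 is therefore estimated at 12 nM, with a range from 4 nM to 40 nM.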

Compound 3, inhibition constant: 8.3 nM
The estimate for compound 3 lay 1.4-fold (0.16 log units) above the measured number, and the stated range covers the measured number.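

In this assay the exchange of 3-fluorophenyl for 3-methylphenyl is a 1.5-fold lower number from compound 2 to compound 3 (0.17 log units; within the scatter) and so moves the reading by no more than repeated measurements of one compound would. Going by these compounds alone, this is the first measured pair for this exchange, and it shows that at this place on the six-membered aromatic ring, fluoro and methyl, each a single heavy atom, are not told apart by this read-out. The data shown give no explanation of why the two groups read alike.

On these data alone, only these two small groups have been compared at this position, so what a larger group such as methoxy or trifluoromethyl, or an amine, would do there remains open. It is also unknown whether the same exchange would read alike when another part of the molecule differs.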